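The source may hold more compounds than are shown below. What is called first, only, known or untested is meant among the compounds shown, and "the series" means these compounds.

Values so far in a functional assay on NCI-H460 cells (Homo sapiens) for cytotoxicity, read by MTT assay, with a stated time of 72 h; a lower number here means a stronger inhibitor, a higher number a weaker inhibitor:

- compound 1 `COc1cc(/C=C2\CN(C)C/C(=C\c3cc(OC)c(OC)c(OC)c3)C2=O)cc(OC)c1OC` gives 1000 nM
- compound 2 `CCCN1C/C(=C\c2ccc(OC)c(OC)c2)C(=O)/C(=C/c2ccc(OC)c(OC)c2)C1` gives 4100 nM
- compound 3 `CCN1C/C(=C\c2ccc(OC)c(OC)c2)C(=O)/C(=C/c2ccc(OC)c(OC)c2)C1` gives 3600 nM

Compound 1 has the lowest number of the three, and its gap to each of the other two lies beyond the scatter. Compound 4 `CCC(=O)N1C/C(=C\c2cc(OC)c(OC)c(OC)c2)C(=O)/C(=C/c2cc(OC)c(OC)c(OC)c2)C1` has not been measured yet. It keeps the core of compound 1 and alters one group, with propanoyl in place of methyl on an amine nitrogen in a ring.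

For the measured compounds named here, only one measured step bears on this change: a 1.1-fold lower number from compound 2 to compound 3 (0.06 log units; within the scatter). That step is small, but it only shortens a plain chain on the amine nitrogen and brings in no carbonyl, so it is a weak guide. Going by the values given here, no measured compound carries propanoyl, and the data cannot settle the direction. A step beyond the scatter is therefore not expected, and the estimated change is a 1.7-fold lower number from compound 1 to compound 4 (0.22 log units; within the scatter) in this assay. The range stays wide on both sides. For compound 4 the expected value is 600 nM, with an estimated range from 150 nM to 2500 nM.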

Compound 4, half-maximal inhibitory concentration: 2700 nM
For compound 4 the middle estimate is 4.5-fold (0.65 log units) below the measured one; measured number above the stated range.
By their numbers in this assay, from the lowest: compound 1; then compounds 4, 3 and 2 (each within the scatter of the next).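

In this assay the group on the amine nitrogen in the ring does matter: propanoyl in place of methyl gives a 2.7-fold higher number from compound 1 to compound 4 (0.43 log units; beyond the scatter) on the core of compound 1. For the compounds shown here, the only earlier change at this nitrogen, a shorter plain chain on a different core, gave a 1.1-fold lower number from compound 2 to compound 3 (0.06 log units; within the scatter), so compound 4 is the first sign that this position can respond, and here the response is towards a weaker inhibitor. Nothing measured here explains why the number rises.

Propanoyl differs from methyl both in carrying a carbonyl and in having more heavy atoms, and the compounds shown cannot separate these two features. On these data alone, how acetyl, a plain propyl chain or a chain ending in an amine on this nitrogen would behave on the core of compound 1 remains open.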